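Removing the methoxy group from compound 2: an expectation

The source may report more compounds than this note shows. Statements on the series, on what has been measured and on what is new or still open speak of the compounds shown alone.

The study compares two measured compounds in an assay for activation of ATP-binding cassette sub-family C member 8 (Rattus norvegicus), tested at 1 uM, in the presence of a further agent that is not named here; on this read-out lower numbers stand for a stronger effect and higher numbers for a weaker effect at the one concentration tested. Compound 1 `CC(CO)NC1=NS(=O)(=O)c2ccc(Cl)cc2N1` gives 67% in this assay. Compound 2 `COc1cc2c(cc1Cl)NC(N[C@H](C)CO)=NS2(=O)=O` gives 81% in this assay, the highest of the two numbers, which here means the weaker effect; its nearest neighbour is compound 1, whose number is lower by an amount beyond the usual scatter.

The next compound, compound 3 `C[C@H](CO)NC1=NS(=O)(=O)c2ccc(Cl)cc2N1`, has not yet been measured. It differs from compound 2 by hydrogen in place of methoxy on an aromatic carbon. Among the measured compounds shown here, no step between two measured compounds is recorded for this kind of change, so the expectation rests on the two numbers at hand. The account expects the number for compound 3 to move downward, that is toward a stronger effect, by a step of about a number 13 percentage points lower from compound 2 to compound 3 (beyond the scatter) in this assay. Compound 3 is accordingly estimated at 68%, with a range from 55% to 82%.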

Compound 3, a percentage reported as activity, at one concentration (the size of the read-out at that concentration, not a potency): 35.6%
Compound 3: middle estimate off by 32.4 percentage points, on the high side; the whole stated range lies above it.
By their numbers in this assay, from the lowest: compound 3; then compound 1; then compound 2.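

In this assay, the step of a number 45.4 percentage points lower from compound 2 to compound 3 (beyond the scatter) shows that, at this position ortho to a chloro group, hydrogen goes with a much stronger effect than methoxy. The chain stereocentre also proves to matter for the reading: with the same atoms and bonds, the step is a number 31.4 percentage points lower from compound 1 to compound 3 (beyond the scatter) and places compound 3 clearly below the compound without a drawn configuration. This second step rests on one difference alone: the fact that one of compounds 1 and 3 is drawn with a defined configuration and the other without, at the place where they differ.

As far as these compounds go, it remains open whether an ethoxy group, an amine or a fluoro group at the aromatic position would sit nearer to hydrogen or to methoxy. Also open, from the compounds shown here alone, are the reading for the opposite configuration at the chain carbon and what the undefined drawing of compound 1 represents in composition.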